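A few compounds are considered here, and "the series" means these few. Any claim that something is new, unique, unknown or untested is made for them only; others in the source may bear on it.

Measured compounds:
compound 1, `Cc1cccc(C#Cc2ccc3c(n2)CCN(C)C3=O)c1`, 820 nM in an assay on HEK293 cells for displacement of a labelled ligand from metabotropic glutamate receptor 5 (Homo sapiens), with a stated time of 2 h; on this read-out higher numbers stand for weaker inhibition and lower numbers for stronger inhibition;
compound 2, `CN1CCc2nc(C#Cc3ccc(Cl)cc3)ccc2C1=O`, 6150 nM in this assay.

Compound 2 stands at the highest of the two numbers in this assay; its nearest neighbour is compound 1, and the step of a 7.5-fold higher number from compound 1 to compound 2 (0.88 log units; beyond the scatter).

Compound 3, `CN1CCc2nc(C#Cc3ccccn3)ccc2C1=O`, has not yet been measured. Relative to compound 2 the change is pyridin-2-yl in place of 4-chlorophenyl on a triple-bonded carbon. Within the data shown here, no measured step covers this exchange: the only step available, a 7.5-fold higher number from compound 1 to compound 2 (0.88 log units; beyond the scatter), concerns a different pair of groups on the same triple-bonded carbon, and shows only that the group there can move the number by a modest amount. That step leaves the direction for a pyridin-2-yl unknown. The expectation for compound 3 therefore rests on wide uncertainty, with a step of a 3.1-fold lower number from compound 2 to compound 3 (0.49 log units; beyond the scatter) expected. Compound 3 is therefore estimated at 2000 nM, within 300 nM to 12000 nM.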

Compound 3, inhibition constant: 6240 nM
The estimate for compound 3 lay 3.1-fold (0.49 log units) below the measured number; measured number inside the range.
By their numbers in this assay, from the lowest: compound 1; then compounds 2 and 3 (each within the scatter of the next).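

In this assay, the exchange on the triple-bonded carbon gives a 1.0-fold higher number from compound 2 to compound 3 (0.01 log units; within the scatter) and so does not separate pyridin-2-yl from 4-chlorophenyl, although pyridin-2-yl brings a ring nitrogen and a hydrogen-bond acceptor. Against 3-methylphenyl, pyridin-2-yl gives a 7.6-fold higher number from compound 1 to compound 3 (0.88 log units; beyond the scatter) and thus a second group at this position reads well apart from compound 1, which alone holds the lowest number of the three. Nothing measured here bears on the reason for this result.

From the compounds shown here alone, how a plain phenyl would read on this triple-bonded carbon stays open, so the contribution of the methyl group cannot be separated from that of the ring carrying it. Also open, going by these compounds, is whether a methyl or methoxy group on the pyridin-2-yl ring would bring the number closer to that of compound 1.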